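Cytotoxicity notes on the aryl-amine series, compound 3

A few compounds are considered here, and "the series" means these few. Any claim that something is new, unique, unknown or untested is made for them only; others in the source may bear on it.

Measured so far:
- compound 1 `CC(C)(C)Nc1c(-c2ccccn2)nc2c(OCc3ccccc3)cccn12`: in an ADME assay on THP-1 cells (Homo sapiens) for cytotoxicity (on this read-out lower numbers stand for higher toxicity in this test and higher numbers for lower toxicity in this test), compound 1 gives > 50000 nM, a limit of the assay, not a number.
- compound 2 `CC(C)(O)CNc1c(-c2ccccn2)nc2ccccn12`: in this assay compound 2 gives > 50000 nM, likewise only a limit of the assay.

Within the data shown here, compound 2 thus stands at the limit of > 50000 nM in this assay, at which 2 of the 2 values shown sit; no number separates it from compound 1, and no step between measured compounds can be sized from these data. Compound 3 `Fc1cccc(Nc2c(-c3ccccn3)nc3ccccn23)c1` differs from compound 2 by 3-fluorophenyl in place of 2-hydroxy-2-methylpropyl on a nitrogen on an aromatic ring, in words 3-fluorophenyl in place of 2-hydroxy-2-methylpropyl on a nitrogen on an aromatic ring. Among the measured compounds shown here, no measured step informs this change, so in this assay the expected step that the limit leaves unreadable from compound 2 to compound 3 is none beyond the scatter. Compound 3 is accordingly expected near 60000 nM, within 20000 nM to 150000 nM, and most likely to be reported again only as a limit.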

Compound 3, half-maximal cytotoxic concentration: > 50000 nM
Compound 3 ended at the assay's limit; the forecaster's own chance of this, stated with the estimate: 75%; the middle value is on the limit's open side.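

The step from compound 2 to compound 3 cannot be read, as both values are limits of the assay and not numbers: the limit of > 50000 nM in this assay, at which 3 of the 3 values shown sit.

The compounds shown leave open whether any change on the shared core, 3-fluorophenyl included, gives a readable value in this assay.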